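The compounds below may be only part of what the source reports. "The series", "measured", "known", "first", "only" and "open" are said of these compounds alone.

Compound 1 `CNc1nc(NCC(C)(C)C)cc(-c2ccccn2)n1`: 73 nM
Compound 2 `c1ccc(-c2cc(NCC3CC3)ncn2)nc1`: 22000 nM
Compound 3 `CC(C)(C)CNc1nc(NCC2CC2)cc(-c2ccccn2)n1`: 5000 nM

All three were measured in a functional assay on HEK293 cells for agonist activity at G-protein coupled receptor 39 (Homo sapiens), read by inositol phosphate accumulation; on this read-out lower numbers stand for an effect already at smaller amounts and higher numbers for an effect only at larger amounts of compound. Compound 3 stands second highest of the three numbers, nearest to compound 2 and far from compound 1. Compound 4 `CNc1nc(NCC2CC2)cc(-c2ccccn2)n1` differs from compound 3 by hydrogen in place of tert-butyl on a saturated chain carbon bound to a nitrogen on an aromatic ring. Among the compounds with values here, one measured step bears on this: a 4.4-fold lower number from compound 2 to compound 3 (0.64 log units; beyond the scatter), which added the whole neopentylamino group. Removing its tert-butyl part runs the opposite way, though only partly. Compound 1 carries methylamino in place of the neopentylamino of compound 3, yet it differs in a second spot as well, so its value gives only a hint. A moderate downward step is expected, a 4.2-fold lower number from compound 3 to compound 4 (0.62 log units; beyond the scatter). Compound 4 is therefore estimated at 1200 nM, between 300 nM and 5000 nM.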

Compound 4, half-maximal effective concentration: 164 nM
Estimate against measurement, compound 4: 7.3-fold (0.86 log units) above; measured number outside the range, below it.
By their numbers in this assay, from the lowest: compound 1; then compound 4; then compound 3; then compound 2.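

In this assay, hydrogen in place of tert-butyl brings a 30-fold lower number from compound 3 to compound 4 (1.48 log units; beyond the scatter) and so the tert-butyl part is not needed for a low number at this place. Methylamino in place of hydrogen on that aromatic carbon gives a 130-fold lower number from compound 2 to compound 4 (2.13 log units; beyond the scatter) and goes far beyond a 4.4-fold lower number from compound 2 to compound 3 (0.64 log units; beyond the scatter) on the same carbon. With methylamino present, cyclopropyl in place of tert-butyl on the other chain gives only a 2.2-fold higher number from compound 1 to compound 4 (0.35 log units; beyond the scatter) as a modest change.

Going by these compounds, whether ethylamino or dimethylamino would keep the number as low remains open. Nothing measured here explains why the smaller methylamino gives the lower number.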